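This account rests on a few compounds, and the source may have more. Where it says the series, first, only, none or still open, it means among the compounds named here.

Working notes on the series. Three compounds on the shared core have numbers in a functional assay on isolated protein for inhibition of Glucose-dependent insulinotropic receptor (Homo sapiens), read by HTRF and cAMP accumulation; on this read-out higher numbers stand for an effect only at larger amounts of compound and lower numbers for an effect already at smaller amounts. For the measured compounds named here, compound 1 `Cc1nc(S(C)(=O)=O)ccc1Oc1ncnc(OC2CCN(C(=O)O[C@@H](C)CF)CC2)c1F` gives 186 nM and stands highest of the three numbers measured so far; its nearest neighbour is compound 2 and its furthest is compound 3. Compound 2 `Cc1nc(S(C)(=O)=O)ccc1Oc1ncnc(OC2CCN(C(=O)SC(C)C)CC2)c1F` gives 6.8 nM. Compound 3 `Cc1nc(S(C)(=O)=O)ccc1Oc1ncnc(OC2CCN(C(=O)SC(C)(C)C)CC2)c1F` gives 4.83 nM. The two steps away from compound 1 are both large: a 27-fold lower number from compound 1 to compound 2 (1.44 log units; beyond the scatter), and a 39-fold lower number from compound 1 to compound 3 (1.59 log units; beyond the scatter); in each case a sulfur-containing group without a ring replaces the group of 3 carbon, 1 oxygen and 1 fluorine on the carbonyl carbon. Between the two sulfur compounds the step is small: a 1.4-fold lower number from compound 2 to compound 3 (0.15 log units; within the scatter).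

Compound 4 `Cc1nc(S(C)(=O)=O)ccc1Oc1ncnc(OC2CCN(C(=S)OC(C)C)CC2)c1F` has not yet been measured in this assay. Compared with compound 1 the change is a group of 6 heavy atoms (4 carbon, 1 oxygen, 1 sulfur; no ring) in place of a group of 7 heavy atoms (4 carbon, 2 oxygen, 1 fluorine; no ring), on an amine nitrogen in a ring. Again fluorine and one oxygen leave and a sulfur enters at the same amine nitrogen in a ring, so the two large steps from compound 1 bear directly on this step, though the entering group of 6 heavy atoms is not the same arrangement as in compound 2 or compound 3, which widens the uncertainty. A large step to a lower number is therefore expected for compound 4, a 12-fold lower number from compound 1 to compound 4 (1.09 log units; beyond the scatter). Compound 4 is estimated at 15 nM, with an expected range from 4 nM to 60 nM.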

Compound 4, half-maximal effective concentration: 69.9 nM
For compound 4 the middle estimate is 4.7-fold (0.67 log units) below the measured one; measured number outside the range, above it.
By their numbers in this assay, from the lowest: compounds 3 and 2 (each within the scatter of the next); then compound 4; then compound 1.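

In this assay, the group of 6 heavy atoms on the amine nitrogen in a ring of compound 4 holds the same 4 carbon, 1 oxygen and 1 sulfur as the group in compound 2, yet the number rises (a 10-fold higher number from compound 2 to compound 4 (1.01 log units; beyond the scatter)), so at this position the arrangement of these atoms matters and the atom count alone does not settle the number. Sulfur in the entering group is also not enough on its own to reach the low numbers of the two earlier sulfur compounds: compound 4 stands well apart from the tert-butyl-bearing compound 3 (a 14-fold higher number from compound 3 to compound 4 (1.16 log units; beyond the scatter)) and keeps only a modest gain over the fluorine-bearing compound 1 (a 2.7-fold lower number from compound 1 to compound 4 (0.43 log units; beyond the scatter)). Nothing available gives a measured reason for the gap between these arrangements.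

The step from compound 1 changes fluorine, oxygen and sulfur content together, so the compounds shown do not assign its size to any one of them. A plain isopropyl carbamate, or a group with sulfur in both positions of the dithiocarbamate, would help separate these contributions on the shared core.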